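A few compounds are considered here, and "the series" means these few. Any claim that something is new, unique, unknown or untested is made for them only; others in the source may bear on it.

Measured so far in a functional assay on SW-620 cells (Homo sapiens) for antiproliferative activity, read by MTT assay, with a stated time of 72 h; on this read-out higher numbers stand for weaker inhibition and lower numbers for stronger inhibition:
- compound 1 `O=c1[nH]c(=O)n(CCC(CO)CO)cc1-c1ccco1`: > 100000 nM
- compound 2 `CCCCCc1ccc(C#Cc2cn(CCC(COC(C)=O)COC(C)=O)c(=O)n(C(=O)c3ccccc3)c2=O)cc1`: > 100000 nM
- compound 3 `CC(=O)OCC(CCn1cc(C#CC(C)(C)C)c(=O)n(C(=O)c2ccccc2)c1=O)COC(C)=O`: > 100000 nM

Compound 1 gives no number in this assay, only a limit, > 100000 nM. Compound 2 likewise stops at a limit, > 100000 nM. Compound 3 also stops at a limit, > 100000 nM. Every value shown is therefore a limit, as summarised by the limit of > 100000 nM in this assay, at which 3 of the 3 values shown sit, and compound 1 cannot be placed above or below any other compound on the numbers available.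

For the measured compounds named here, only one pair of measured compounds differs in a single place, and that step, a step that the two limits leave unreadable from compound 2 to compound 3, replaces one group on a triple-bonded carbon with another; its size cannot be read from two limits.

Compound 4 `O=c1[nH]c(=O)n(CCC(CO)CO)cc1C#CCCCCl` differs from compound 1 in one place: 5-chloropent-1-yn-1-yl in place of furan-2-yl on an aromatic carbon. Going by the values given here, no measured step bears on this exchange with a readable size, so the data give no direction for it. The expectation is that the step of a number no higher from compound 1 to compound 4 (the limit leaves the size open) stays unreadable, with compound 4 most likely reported as a limit again. Compound 4 is therefore estimated at 100000 nM, with a range from 20000 nM to 300000 nM.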

Compound 4, half-maximal inhibitory concentration: > 100000 nM
Compound 4 gave a limit, no number (the forecaster's own chance of this, stated with the estimate: 70%); the middle value sits exactly at the limit.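

In this assay compound 4 stops at a limit, as compound 1 does, so no step can be read between compound 1 and compound 4, and every value shown is the same limit: the limit of > 100000 nM in this assay, at which 4 of the 4 values shown sit. The compounds shown leave open how strongly any of them inhibits, and whether exchanging the group on that aromatic carbon changes anything.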